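The source may report more compounds than this note shows. Statements on the series, on what has been measured and on what is new or still open speak of the compounds shown alone.

Compounds measured so far:
compound 1, `CC[C@H](C)[C@H](NC(=O)CN(c1nc(Cl)nc2[nH]cnc12)C1CC1)C(=O)O`, 21.4%
compound 2, `NC(=O)C[C@H](NC(=O)CN(c1nc(Cl)nc2[nH]cnc12)C1CC1)C(=O)O`, 17%
compound 3, `NCCCC[C@H](NC(=O)CN(c1nc(Cl)nc2[nH]cnc12)C1CC1)C(=O)O`, 16.4%

All three were tested in a functional assay on the whole organism (Tail, strain ICR) with Mus musculus as the target, in the tail flick test, with a stated time of 120 min, at a dose of 25 umol/kg by the oral route; on this read-out lower numbers stand for a weaker effect and higher numbers for a stronger effect at the one dose given. Compound 3 holds the smallest of the three numbers, but its nearest neighbour is compound 2 at 17% and the gap to compound 1 at 21.4% is also small: a number 0.6 percentage points lower from compound 2 to compound 3 (within the scatter) and a number 5 percentage points lower from compound 1 to compound 3 (within the scatter) both sit inside the scatter, so the three compounds cannot be separated on this read-out.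

Compound 4, `CC(C)C[C@H](NC(=O)CN(c1nc(Cl)nc2[nH]cnc12)C1CC1)C(=O)O`, has not yet been measured. It differs from compound 3 as follows: isopropyl in place of 3-aminopropyl on a saturated chain carbon, two bonds along the chain from an amide-type nitrogen and a carbonyl carbon. For the measured compounds named here, the steps that bear on this change are those already seen at the same position. Going from compound 1 to compound 3 replaced sec-butyl with 4-aminobutyl and gave a number 5 percentage points lower from compound 1 to compound 3 (within the scatter); going from compound 2 to compound 3 gave a number 0.6 percentage points lower from compound 2 to compound 3 (within the scatter). Neither swap at this carbon moved this assay beyond its scatter, so the reverse direction, back to a plain branched alkyl in compound 4, is expected to give no step beyond the scatter either, at most a small rise: a number 3.6 percentage points higher from compound 3 to compound 4 (within the scatter).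

Compound 4 is therefore estimated at 20% in this assay, within a range from 10% to 30%.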

Compound 4, a percentage reported as activity, at one dose (the size of the read-out at that dose, not a potency): 18.7%
Beside the measured number, compound 4's estimate is 1.3 percentage points above it, within the range that was stated.
By their numbers in this assay, from the lowest: compounds 3, 2, 4 and 1 (each within the scatter of the next).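

In this assay, replacing the 3-aminopropyl of compound 3 with the isopropyl of compound 4 gives a number 2.3 percentage points higher from compound 3 to compound 4 (within the scatter) and removes the amine from the side chain, so an amine at this saturated chain carbon is not needed for a number in this range. The same holds for the carbamoyl end group, where isopropyl in its place gives a number 1.7 percentage points higher from compound 2 to compound 4 (within the scatter) and again leaves the compounds unseparated, and for the arrangement of the alkyl chain, where the isobutyl of compound 4 in place of the sec-butyl of compound 1 gives a number 2.7 percentage points lower from compound 1 to compound 4 (within the scatter) as the third step inside the scatter. Nothing measured alongside these numbers speaks to why the side chain makes so little difference here.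

All four compounds therefore stand together at one dose and one time point, and these numbers cannot show whether any of these side chains would differ at another dose or time. On these data alone, whether a phenyl ring, a carboxylic acid or a longer chain at this carbon would move this assay beyond the scatter remains open.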